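The compounds below may be only part of what the source reports. "The series", "measured", "known", "first", "only" and "open" are said of these compounds alone.

The study follows antiproliferative activity in a functional assay on HBL-100 cells (Homo sapiens) for antiproliferative activity, read by luminescence and CellTiter-Glo, with a stated time of 48 h; a lower number here means a stronger inhibitor, a higher number a weaker inhibitor. Compound 1 `COc1ccc(/C=C/[C@H]2CC=CC(=O)O2)cc1` gives only a limit in this assay, > 100000 nM. Compound 3 `O=C1C=CC[C@@H](/C=C/c2ccc(F)cc2)O1` likewise gives only a limit in this assay, > 100000 nM. Two of the three values shown are therefore limits: the limit of > 100000 nM in this assay, at which 2 of the 3 values shown sit. Among the compounds with values here, compound 2 `O=C1C=CC[C@@H](/C=C/C2CCCCC2)O1` stands apart as the one compound with an actual number; in this assay compound 2 gives 48200 nM, so it is the only measured value on which a comparison can rest.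

Compound 4 `O=C1C=CC[C@H](/C=C/C2CCCCC2)O1` has not been measured in this assay. It has the same atoms and bonds as compound 2 and differs only in configuration as drawn: the two compounds have the same atoms and bonds and differ only in configuration as drawn: 1 of 2 stereo elements differ; a stereocentre at a saturated ring carbon is drawn S in compound 2 and R in compound 4. No pair of measured compounds differs by a single change, so the numbers shown say nothing about what a change of configuration at this stereocentre does to potency. A step in either direction is possible, including a loss of the measurable number altogether. Compound 4 is expected to be a somewhat weaker inhibitor than compound 2, an expected step of a 1.5-fold higher number from compound 2 to compound 4 (0.16 log units; within the scatter). Compound 4 is estimated at 70000 nM, with a range from 30000 nM to 200000 nM.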

Compound 4, half-maximal inhibitory concentration: 29000 nM
Estimate against measurement, compound 4: 2.4-fold (0.38 log units) above; measured number below the stated range.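

Within the data shown here, this pair gives the first step in this assay that can be read at a single change: a 1.7-fold lower number from compound 2 to compound 4 (0.22 log units; within the scatter). At this stereocentre on a saturated ring carbon, the S and R drawings therefore cannot be told apart, and the measurable number is kept with either one. The reading isolates this one stereocentre, with no other change mixed in: the fact that compounds 2 and 4 differ only in the configuration as drawn.

Compounds 1 and 3 offer no number for comparison, and their values are limits of the assay: the limit of > 100000 nM in this assay, at which 2 of the 4 values shown sit. Going by these compounds, whether a longer chain, an amine or a carboxylic acid, set in place of the end group shared by compound 2 and compound 4, would shift the number beyond the scatter stays open, as does the effect of the second stereo element.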